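Chloro in Place of Fluoro: What to Expect for Compound 4

The compounds below may be only part of what the source reports. "The series", "measured", "known", "first", "only" and "open" are said of these compounds alone.

Measured in an ADME assay on the whole organism with Oryza sativa as the target, tested at 10 uM; a lower number here means a stronger effect, a higher number a weaker effect of the compound at the concentration tested:
Compound 1, `C[C@@H](NC(=O)Nc1ccccc1F)c1ccccc1`: 77%
Compound 2, `C[C@@H](NC(=O)Nc1cccc(F)c1)c1ccccc1`: 84%
Compound 3, `C[C@@H](NC(=O)Nc1ccccc1Cl)c1ccccc1`: 93%

Compound 1 and compound 2 have the same atoms joined differently; the difference between the two cores is not broken down here. The values of compound 2 and compound 1 lie within the scatter of each other, and so do those of compound 2 and compound 3. From compound 1 to compound 3 the change is chloro in place of fluoro on an aromatic carbon, and this assay records a number 16 percentage points higher from compound 1 to compound 3 (beyond the scatter).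

Compound 4 `C[C@@H](NC(=O)Nc1cccc(Cl)c1)c1ccccc1` has not yet been measured. It differs from compound 2 by chloro in place of fluoro on an aromatic carbon. This is the same kind of change, not the same one: the place is ortho to a large group in compound 3 but meta to a large group in compound 4. Resting on the single measured step of a number 16 percentage points higher from compound 1 to compound 3 (beyond the scatter), the expected step is a number 10 percentage points higher from compound 2 to compound 4 (within the scatter). Compound 4 is therefore estimated to give 94% in this assay. Its expected range runs from 82% to 100%.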

Compound 4, a percentage reported as activity, at one concentration (the size of the read-out at that concentration, not a potency): 83%
The estimate for compound 4 lay 11 percentage points above the measured number, within the range that was stated.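

Chloro in place of fluoro on an aromatic carbon gave a number 1 percentage points lower from compound 2 to compound 4 (within the scatter) in this assay. The size of this step therefore did not carry over from one core to the other in this series: the same change on two cores in this assay, a number 16 percentage points higher (beyond the scatter) from compound 1 to compound 3 and a number 1 percentage points lower (within the scatter) from compound 2 to compound 4, 17 percentage points apart, beyond the scatter of two such steps

With a single pair on each core, this shows that the earlier step cannot simply be transferred, but it does not show how the change would behave on any further core or which difference between the two cores accounts for the gap.

The compounds shown carry only fluoro and chloro on this aromatic ring. They leave open how a methoxy group or a nitrile in the same places would read in this assay.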